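The compounds below may be only part of what the source reports. "The series", "measured", "known", "first", "only" and "open" are said of these compounds alone.

In an assay on HEK293 cells for displacement of a labelled ligand from corticotropin-releasing factor receptor 1 (Homo sapiens), read by scintillation proximity assay, with a stated time of 2 h (on this read-out higher numbers stand for weaker inhibition and lower numbers for stronger inhibition), compound 2 `CCN(CC1CCOCC1)c1cccc2nc(Oc3c(OC)cc(COC)cc3OC)c(C)cc12` gives 646 nM. Compound 1 `CCCN(CCC)c1cccc2nc(N(C)c3c(C)cc(C)cc3C)c(=O)n(C)c12` gives > 1000 nM, which is a limit of the measurement rather than a number, so the limit of > 1000 nM in this assay, at which 1 of the 2 values shown sits, covers it. Compound 2 therefore stands as the only finished number among the two results shown, with nothing measured to rank it against.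

Compound 3 `CCN(CC)c1cccc2nc(Oc3c(OC)cc(COC)cc3OC)c(C)cc12` shares the core of compound 2 and differs in one place: methyl in place of oxan-4-yl on a saturated chain carbon bound to a nitrogen on an aromatic ring, so that the ethyl((oxan-4-yl)methyl)amino group becomes a diethylamino group. Within the data shown here, no measured pair shows what such a change does here, so the expectation rests on compound 2 alone. A modest step toward weaker binding, or none beyond the usual scatter, is expected, written as a 1.4-fold higher number from compound 2 to compound 3 (0.14 log units; within the scatter). Compound 3 is accordingly estimated at 900 nM, with a likely range from 250 nM to 3000 nM, and a fair chance that only a limit is reported.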

Compound 3, half-maximal inhibitory concentration: 70 nM
Compound 3: the middle estimate sits 13-fold (1.11 log units) above what was measured; measured number outside the range, below it.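

Replacing oxan-4-yl with methyl on a saturated chain carbon bound to a nitrogen on an aromatic ring gives a 9.2-fold lower number from compound 2 to compound 3 (0.97 log units; beyond the scatter) in this assay, so what sits at this position does matter. The earlier compounds shown here offered no pair differing in one place, whereas this one shows that the oxan-4-yl ring is not required for binding in this assay series, since the diethylamino compound has the lower number. Nothing measured here gives a cause for this step.

The compounds shown leave open whether the ring as a whole or its oxygen accounts for the difference, and a cyclohexyl group in the same place would separate those two. They also leave open how a longer chain, such as butyl in place of ethyl, would read.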